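This account rests on a few compounds, and the source may have more. Where it says the series, first, only, none or still open, it means among the compounds named here.

In a functional assay on Caco-2 cells (Homo sapiens) for antiproliferative activity, read by MTT assay, with a stated time of 48 h (a lower number here means a stronger inhibitor, a higher number a weaker inhibitor), compound 1 `CCn1c(C(=O)NCCCN(C)C)ccc1C(CC)(CC)c1ccc(OCCC(O)(CC)CC)c(C)c1` gives 490 nM. Compound 2 `C#CCCOC(=O)c1ccc(C(CC)(CC)c2ccc(OCCC(O)(CC)CC)c(C)c2)n1CC` gives > 50000 nM, which is a limit of the assay and not a number. Compound 3 `CCn1c(C(=O)Nc2ccc(OC(F)(F)F)cc2)ccc1C(CC)(CC)c1ccc(OCCC(O)(CC)CC)c(C)c1` gives > 50000 nM, which is also a limit. Compound 4 `CCOC(=O)C(CC(=O)OC)NC(=O)c1ccc(C(CC)(CC)c2ccc(OCCC(O)(CC)CC)c(C)c2)n1CC` differs from compound 3 as follows: a group of 11 heavy atoms (7 carbon, 4 oxygen; no ring) in place of a group of 11 heavy atoms (7 carbon, 1 oxygen, 3 fluorine; one six-membered aromatic ring of carbon only), on an amide-type nitrogen. Neither group carries a net charge. Among the measured compounds shown here, two measured steps bear on this change, both large: an at least 100-fold higher number from compound 1 to compound 3 (2.00 log units; beyond the scatter) and an at least 100-fold higher number from compound 1 to compound 2 (2.00 log units; beyond the scatter). Each removes the 3-(dimethylamino)propyl group, which compound 4 also lacks. For the measured compounds named here, no large step is therefore expected in this assay, and compound 4 is expected to stay close to the limit reached by compound 3 at > 50000 nM. The expected change is an at least 1.2-fold lower number from compound 3 to compound 4 (0.09 log units; that floor lies within the scatter). The estimate for compound 4 is 40000 nM, with an expected range from 12000 nM to 100000 nM.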

Compound 4, half-maximal inhibitory concentration: 3020 nM
Compound 4: the middle estimate sits 13-fold (1.12 log units) above what was measured, and the stated range ends above it.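

Compound 4 shows that a measurable effect in this assay does not need the 3-(dimethylamino)propyl group on the amide-type nitrogen: the uncharged, ring-free group gives an at least 16-fold lower number from compound 3 to compound 4 (1.21 log units; beyond the scatter), and also an at least 16-fold lower number from compound 2 to compound 4 (1.21 log units; beyond the scatter). Replacing the 3-(dimethylamino)propyl group with this group still costs potency, with a 6.2-fold higher number from compound 1 to compound 4 (0.79 log units; beyond the scatter). The two steps from the limit compounds are floors, not full sizes: the limit of > 50000 nM in this assay, at which 2 of the 4 values shown sit.

The step between compound 2 and compound 3 cannot be read. Open, as far as these compounds go, is how a carboxylic acid, a primary amine or a longer amine chain on this nitrogen would compare.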